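Exchanging 4-fluorophenyl for 4-chlorophenyl in an antiproliferative series

This account rests on a few compounds, and the source may have more. Where it says the series, first, only, none or still open, it means among the compounds named here.

In a functional assay on A549 cells (Homo sapiens) for antiproliferative activity, read by MTT assay, with a stated time of 48 h (on this read-out higher numbers stand for weaker inhibition and lower numbers for stronger inhibition), compound 1 (`c1ccc(-c2nn(-c3ccccc3)cc2-c2nc3ccccc3[nH]2)cc1`) gives 2710 nM, compound 2 (`Fc1ccc(-c2nn(-c3ccccc3)cc2-c2nc3ccccc3[nH]2)cc1`) gives 1510 nM and compound 3 (`Fc1ccc(-c2nn(-c3ccccc3)cc2-c2nc3cc(F)ccc3[nH]2)cc1`) gives 1130 nM. Compound 2 therefore holds the middle of the three numbers, and it lies within the scatter of both compound 1 and compound 3.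

Compound 4 (`Clc1ccc(-c2nn(-c3ccccc3)cc2-c2nc3ccccc3[nH]2)cc1`) has not yet been measured. It differs from compound 2 in a single place: chloro in place of fluoro on an aromatic carbon. This is chloro in place of fluoro on an aromatic carbon, para to a large group, which turns 4-fluorophenyl into 4-chlorophenyl.

Among the compounds with values here, no measured step makes this exact exchange, so the evidence is indirect. Fluoro in place of hydrogen at this same place gave a 1.8-fold lower number from compound 1 to compound 2 (0.25 log units; within the scatter). A further fluoro in place of hydrogen, elsewhere on the shared core, gave a 1.3-fold lower number from compound 2 to compound 3 (0.13 log units; within the scatter). Both steps stay within the scatter, and neither says anything directly about chloro. With only these two steps to go on, no change beyond the scatter is expected in this assay, in either direction. The expected step is small, a 1.1-fold lower number from compound 2 to compound 4 (0.03 log units; within the scatter). Compound 4 is estimated at 1400 nM, with an expected range from 700 nM to 2800 nM.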

Compound 4, half-maximal inhibitory concentration: 5960 nM
For compound 4 the middle estimate is 4.3-fold (0.63 log units) below the measured one; the measured number lies above the stated range.
By their numbers in this assay, from the lowest: compounds 3, 2 and 1 (each within the scatter of the next, the first and the last beyond it); then compound 4.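

In this assay, within the data shown here, this position proves sensitive to which halogen it carries: exchanging 4-fluorophenyl for 4-chlorophenyl gives a 3.9-fold higher number from compound 2 to compound 4 (0.60 log units; beyond the scatter), a modest step but one that passes beyond the scatter, as no earlier step did. Measured against hydrogen at the same place, chloro gives a 2.2-fold higher number from compound 1 to compound 4 (0.34 log units; beyond the scatter), whereas fluoro in place of hydrogen there stayed within the scatter, so on this read-out chloro weakens inhibition at this place and the two halogens do not behave alike. Nothing in the data shown accounts for this difference between chloro and fluoro.

The compounds shown carry only hydrogen, fluoro or chloro at this place, so it remains open how a bromo, a methoxy or an amino group there would compare with them. As far as these compounds go, it also remains open whether the exchange of fluoro for chloro would give a step of similar size and direction on the core of compound 3, with its further fluoro present.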